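Amine variation on the shared core: compound 3 to compound 4

A few compounds are considered here, and "the series" means these few. Any claim that something is new, unique, unknown or untested is made for them only; others in the source may bear on it.

Three compounds are in hand. Compound 1 `CC(C(=O)NCc1ccc(C(F)(F)F)nc1N(C)C)c1ccc(NS(C)(=O)=O)c(F)c1` gives 19.1 nM in a functional assay on CHO-K1 cells for antagonist activity at transient receptor potential cation channel subfamily V member 1 (Homo sapiens), read by FLIPR; a higher number here means a weaker inhibitor, a lower number a stronger inhibitor. Going by the values given here, compound 2 `CC(C(=O)NCc1ccc(C(F)(F)F)nc1N(C)c1ccccc1)c1ccc(NS(C)(=O)=O)c(F)c1` gives 0.9 nM in this assay, and the single step between measured compounds that differ in one place is a 21-fold lower number from compound 1 to compound 2 (1.33 log units; beyond the scatter). Among the compounds with values here, compound 3 `CC1CCCN1c1nc(C(F)(F)F)ccc1CNC(=O)[C@@H](C)c1ccc(NS(C)(=O)=O)c(F)c1` gives 0.3 nM in this assay, the lowest number of the three, with compound 2 nearest and compound 1 furthest; no single-place step connects compound 3 to either.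

Compound 4 `C[C@H](C(=O)NCc1ccc(C(F)(F)F)nc1N1CC[C@H](N(C)C)C1)c1ccc(NS(C)(=O)=O)c(F)c1` carries 3-(dimethylamino)pyrrolidin-1-yl in place of 2-methylpyrrolidin-1-yl on an aromatic carbon. Within the data shown here, no measured step alters a substituent within the ring on that aromatic carbon. Among the measured compounds shown here, the one measured step, methyl to phenyl on the ring nitrogen, shows that this region of the shared core can shift the number a great deal, yet it says nothing about a dimethylamino group entering a pyrrolidine. The expectation therefore leans on compound 3 alone, with wide uncertainty. A modest weakening is expected in this assay, as compound 3 already holds the lowest number at 0.3 nM and further gains here are unsupported by any step. The change is expected to give a 5.0-fold higher number from compound 3 to compound 4 (0.70 log units; beyond the scatter). Compound 4 is estimated at 1.5 nM, with a range from 0.3 nM to 8 nM.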

Compound 4, inhibition constant: 103 nM
For compound 4 the middle estimate is 69-fold (1.84 log units) below the measured one; the whole stated range lies below it.
By their numbers in this assay, from the lowest: compound 3; then compound 2; then compound 1; then compound 4.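

In this assay, the position on the aromatic carbon next to the ring nitrogen is now shown to move the number strongly in both directions: the only earlier step at this site, on the amine nitrogen, went down, whereas this change gives a 340-fold higher number from compound 3 to compound 4 (2.54 log units; beyond the scatter). Even with the five-membered non-aromatic ring kept, the result therefore depends heavily on what that ring carries, and replacing 2-methylpyrrolidin-1-yl with 3-(dimethylamino)pyrrolidin-1-yl is clearly not tolerated as a neutral swap in this series. No supporting measurement is available to explain the size of this step.

The step removes the methyl and adds the dimethylamino group in one move, so the compounds shown do not separate the contribution of each, and a plain pyrrolidin-1-yl carrying neither group would be the direct link between compound 3 and compound 4. On these data alone, it also remains open how the opposite configuration at the dimethylamino-bearing carbon, or a hydroxyl or methoxy group in place of dimethylamino on the same ring, would read in this assay.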